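Working notes on tolerated concentration, compound 3 to compound 4

The source may hold more compounds than are shown below. What is called first, only, known or untested is meant among the compounds shown, and "the series" means these compounds.

Measured in an ADME assay on MT2 cells (Homo sapiens) for cytotoxicity, read by XTT assay, with a stated time of 4 days; a higher number here means that more compound is tolerated, a lower number that less compound is tolerated:
compound 1 `Cc1cc(/C=C2\SC(=S)N(Cc3ccc(C(F)(F)F)cc3)C2=O)c(C)n1-c1ccc(O)c(C(=O)O)c1`: 45900 nM
compound 2 `Cc1cc(/C=C2\SC(=S)N(Cc3ccc(C(=O)O)cc3)C2=O)c(C)n1-c1ccc(O)c(C(=O)O)c1`: 105000 nM
compound 3 `COc1cccc(CN2C(=O)/C(=C/c3cc(C)n(-c4ccc(O)c(C(=O)O)c4)c3C)SC2=S)c1`: 102000 nM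

Compound 3 stands second highest of the three; the nearest step is a 1.0-fold lower number from compound 2 to compound 3 (0.01 log units; within the scatter), within the scatter, while the furthest is a 2.2-fold higher number from compound 1 to compound 3 (0.35 log units; beyond the scatter). Compound 4 `Cc1cc(/C=C2\SC(=S)N(Cc3ccccc3C(F)(F)F)C2=O)c(C)n1-c1ccc(O)c(C(=O)O)c1` carries 2-(trifluoromethyl)phenyl in place of 3-methoxyphenyl on a saturated chain carbon bound to an amide-type nitrogen in a ring. The step that bears on this is a 2.2-fold higher number from compound 1 to compound 3 (0.35 log units; beyond the scatter), where removing a trifluoromethyl-bearing phenyl raised the number modestly; a 2.3-fold higher number from compound 1 to compound 2 (0.36 log units; beyond the scatter) points the same way. Re-entering trifluoromethyl, now on the 2-position phenyl, is therefore expected to lower the number, by about a 1.9-fold lower number from compound 3 to compound 4 (0.27 log units; within the scatter), though the positional difference from compound 1 leaves this uncertain. Compound 4 is estimated at 55000 nM, range 25000 nM to 120000 nM.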

Compound 4, half-maximal cytotoxic concentration: 28800 nM
Compound 4: the middle estimate sits 1.9-fold (0.28 log units) above what was measured; the range from low to high includes it.
By their numbers in this assay, from the lowest: compounds 4 and 1 (each within the scatter of the next); then compounds 3 and 2 (each within the scatter of the next).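

In this assay, 2-(trifluoromethyl)phenyl in this place gives a 3.5-fold lower number from compound 3 to compound 4 (0.55 log units; beyond the scatter) and a 3.6-fold lower number from compound 2 to compound 4 (0.56 log units; beyond the scatter) and both steps lie beyond the scatter, so this place does respond to the change of aryl group, which the step between 3-methoxyphenyl and 4-carboxyphenyl did not show. The change from 4-(trifluoromethyl)phenyl gives a 1.6-fold lower number from compound 1 to compound 4 (0.20 log units; within the scatter) and leaves these two placements of trifluoromethyl unresolved. No supporting data explain these differences.

Still open, on these data alone, is whether an unsubstituted phenyl or a cyclohexyl group in this place would fall with compound 1 and compound 4 or with compound 2 and compound 3.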